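The source may report more compounds than this note shows. Statements on the series, on what has been measured and on what is new or still open speak of the compounds shown alone.

Compound 3 `COc1ccc(N2CCN(C(=S)SCc3ccc(C(=O)Nc4ccccc4N)cc3)CC2)cc1` gives 52.3% in a functional assay on HeLa cells (Homo sapiens) for antiproliferative activity, read by CCK-8 assay, with a stated time of 72 h, tested at 8 uM (a higher number here means a stronger effect of the compound at the concentration tested, a lower number a weaker effect), the second highest of three numbers: compound 1 `Nc1ccccc1NC(=O)c1ccc(CSC(=S)N2CCN(Cc3ccncc3)CC2)cc1` gives 72.9% and compound 2 `Nc1ccccc1NC(=O)c1ccc(CSC(=S)N2CCN(C(c3ccccc3)c3ccccc3)CC2)cc1` gives 13.8%. Going by the values given here, the only measured step at the amine nitrogen in a ring is a number 20.6 percentage points lower from compound 1 to compound 3 (beyond the scatter). Compound 4 `Nc1ccccc1NC(=O)c1ccc(CSC(=S)N2CCN(Cc3ccccc3)CC2)cc1` differs from compound 3 by benzyl in place of 4-methoxyphenyl on an amine nitrogen in a ring. Among the compounds with values here, no measured step exchanges 4-methoxyphenyl for benzyl on that nitrogen; the expectation rests on compound 1 with 72.9% and compound 3 with 52.3% as the two single-ring substituents measured there, with benzyl taken to fall between them. A small rise is expected, a number 7.7 percentage points higher from compound 3 to compound 4 (within the scatter), within the scatter. Compound 4 is estimated at 60%, in the range 38% to 80%.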

Compound 4, a percentage reported as inhibition, at one concentration (the size of the read-out at that concentration, not a potency): 31.3%
The estimate for compound 4 lay 28.7 percentage points above the measured number; measured number outside the range, below it.
By their numbers in this assay, from the lowest: compound 2; then compound 4; then compound 3; then compound 1.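

In this assay, the benzyl step gives a number 21 percentage points lower from compound 3 to compound 4 (beyond the scatter), so the single-ring substituents on this amine nitrogen do not behave as one group. The largest change comes from phenyl in place of pyridin-4-yl, a number 41.6 percentage points lower from compound 1 to compound 4 (beyond the scatter), whereas hydrogen in place of phenyl on the chain carbon recovers only part of that loss, a number 17.5 percentage points higher from compound 2 to compound 4 (beyond the scatter). No evidence accounts for these differences.

The step from compound 3 to compound 4 alters both the methoxy group and the link to the ring, leaving their separate contributions open. Also open, as far as these compounds go, is whether pyridin-3-yl or 4-methoxybenzyl would hold the level of compound 1.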